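Removing the methoxymethyl group from compound 1

The source may report more compounds than this note shows. Statements on the series, on what has been measured and on what is new or still open speak of the compounds shown alone.

In a physicochemical assay for lipophilicity, read by HPLC, in phosphate buffer, measured as octanol-water partition, with a stated time of 1 h, at pH 7.4 (a higher number here means a more lipophilic compound, a lower number a more polar compound), compound 1 (`COCC1=C[C@@](C)(c2cc(NC(=O)c3ccc(C#N)cn3)ccc2F)N=C(N)O1`) gives 2 as its reading. Among the compounds with values here, only one other compound has a reading in this assay so far: compound 2 (`C[C@@]1(c2cc(NC(=O)c3coc(C(F)F)n3)ccc2F)C=C(CF)OC(N)=N1`) gives 2.6 there. Compound 1 therefore holds the lower of the two numbers, and the gap between them lies beyond the scatter. The two compounds differ in more than one place, so that gap cannot be tied to any single change.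

Compound 3 (`C[C@@]1(c2cc(NC(=O)c3ccc(C#N)cn3)ccc2F)C=COC(N)=N1`) has not yet been measured. It departs from compound 1 in one place: hydrogen in place of methoxymethyl on a double-bonded ring carbon and, put briefly, hydrogen stands in place of methoxymethyl on a double-bonded ring carbon. Within the data shown here, no measured pair shows this change on its own, so the expectation starts from compound 1 at 2 and remains a judgement. The expected move is small and downward, with an estimated size of a number 0.20 log units lower from compound 1 to compound 3 (within the scatter) and no clear departure from the scatter expected. For compound 3 the estimated value is 1.8 within an expected range from 1.3 to 2.3 in this measurement.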

Compound 3, distribution coefficient: 2
The estimate for compound 3 lay 0.20 log units below the measured number; the range from low to high includes it.
By their numbers in this assay, from the lowest: compounds 1 and 3 (each within the scatter of the next); then compound 2.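

In this assay, within the data shown here, this is the first step that isolates a single place: hydrogen in place of methoxymethyl on a double-bonded ring carbon, next to the ring oxygen, gives no change at the digits printed from compound 1 to compound 3 (within the scatter) on the shared core. The whole methoxymethyl group, with its hydrogen-bond acceptor, can therefore leave this carbon without producing a reading that can be told apart from that of compound 1. Nothing else in the data explains why the reading holds at this position.

This conclusion rests on one pair in one assay, and compound 2, which carries fluoromethyl on that carbon, differs from both compound 1 and compound 3 in more than one place, so its reading cannot be set against this step. On these data alone, it remains open whether an amine, a carboxylic acid or a longer chain on the same carbon would leave the reading just as undisturbed, and whether the same replacement would give the same result with a different amide portion.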